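Bromo for iodo on the core of compound 1

The source may report more compounds than this note shows. Statements on the series, on what has been measured and on what is new or still open speak of the compounds shown alone.

Going by the values given here, in a functional assay on HCT-116 cells (Homo sapiens) for cytotoxicity, with a stated time of 3 days (on this read-out higher numbers stand for weaker inhibition and lower numbers for stronger inhibition), compound 1 `Cn1c(I)nc2ccccc21` gives 17500 nM, the only actual number so far. Compound 2 `Ic1nc2ccccc2[se]1` is reported only as a limit, > 40000 nM. The next step leads to compound 3 `Cn1c(Br)nc2ccccc21`, with bromo in place of iodo on an aromatic carbon. Among the compounds with values here, no measured step covers this exchange, and no change beyond the scatter is expected in this assay. The expected step is a 1.3-fold higher number from compound 1 to compound 3 (0.10 log units; within the scatter). Compound 3 is estimated at 22000 nM, within an expected range of 10000 nM to 45000 nM.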

Compound 3, half-maximal inhibitory concentration: > 40000 nM
Compound 3: no number, only a limit (the forecaster's own chance of this, stated with the estimate: 20%); at least 1.8-fold (0.25 log units) between middle value and limit.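

On the aromatic carbon between two ring nitrogen atoms, the exchange is not neutral in this assay: bromo in place of iodo gives an at least 2.2-fold higher number from compound 1 to compound 3 (0.35 log units; beyond the scatter). Compound 3 carries a limit rather than a number, so the true size of this step stays unknown, because the read-out ends there: the limit of > 40000 nM in this assay, at which 2 of the 3 values shown sit.

Going by these compounds alone, with compound 1 the only one giving a number, no trend across groups at this carbon can be drawn. From the compounds shown here alone, whether chloro or an amine at this carbon, or a longer chain in place of the methyl group, would retain the effect of compound 1 remains open.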